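The compounds below may be only part of what the source reports. "The series", "measured", "known", "first", "only" and "open" are said of these compounds alone.

Measured so far:
- compound 1 `NC(=O)c1c(NC(=O)Nc2ccc(Cl)cc2)sc2c1CCN(CC1CCCCC1)C2`: 1890 nM
- compound 2 `C[N+]1(CC2CCCC2)CCc2c(sc(NC(=O)Nc3ccc(Cl)cc3)c2C(N)=O)C1`: 200 nM
- compound 3 `CCN1CCc2c(sc(NC(=O)Nc3ccc(Cl)cc3)c2C(=O)OC)C1`: > 25000 nM

In a functional assay (strain AB) with Danio rerio as the target, read by microscopy, with a stated time of 1 h (a higher number here means that more compound is needed for the effect, a lower number that less compound is needed), compound 2 gives 200 nM, the lower of the two numbers recorded; compound 1 gives 1890 nM, and the gap between compound 1 and compound 2 is beyond the usual scatter of repeated runs. The value for compound 3 in this assay, > 25000 nM, is a limit of the assay and not a number, so compound 3 supplies no point of comparison (the limit of > 25000 nM in this assay, at which 1 of the 3 values shown sits).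

Compound 4 `C[N+]1(CC2CC2)CCc2c(sc(NC(=O)Nc3ccc(Cl)cc3)c2C(N)=O)C1` has not yet been measured. It differs from compound 2 in one place: cyclopropyl in place of cyclopentyl on a saturated chain carbon bound to an amine nitrogen in a ring. Going by the values given here, no pair of measured compounds differs in exactly this way, so the effect of shortening the ring on the saturated chain carbon bound to the ring amine nitrogen is untested here; the pair of compound 1 and compound 2 is not a clean guide, since it changes both the ring size and the charge state of the nitrogen.

The working expectation is a modest rise in the number, a 2.0-fold higher number from compound 2 to compound 4 (0.30 log units; within the scatter), but one that may well fall inside the scatter. Compound 4 is estimated at 400 nM in this assay, with a likely range from 120 nM to 1500 nM.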

Compound 4, half-maximal effective concentration: 360 nM
Compound 4: middle estimate off by 1.1-fold (0.05 log units), on the high side, and the stated range covers the measured number.
By their numbers in this assay, from the lowest: compounds 2 and 4 (each within the scatter of the next); then compound 1. At a limit, above all of these: compound 3.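

In this assay, going by these compounds alone, cyclopropyl in place of cyclopentyl on a saturated chain carbon bound to an amine nitrogen in a ring gives a 1.8-fold higher number from compound 2 to compound 4 (0.26 log units; within the scatter), the first reading at this position with only one place changed. The ring at this place can hold 5 or 3 heavy atoms with no difference that this assay can resolve, so compound 2 and compound 4 stand at one level here. No measured property in the compounds shown bears on this step, and the result remains an observation on this one pair.

As far as these compounds go, whether a benzyl group, an open chain such as isobutyl or a cyclopentyl ring carrying a hydroxyl group would stay at the level of compound 2 and compound 4 remains open, and two ring sizes are too few to state any trend with size. Compound 1 and compound 2 differ in more than one place, which leaves the contribution of the methyl on the ring nitrogen unresolved.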